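The compounds below may be only part of what the source reports. "The series", "measured", "known", "first", "only" and "open" are said of these compounds alone.

Measured in a functional assay on A 172 cells (Homo sapiens) for cytotoxicity, read by MTT assay, with a stated time of 24 h; on this read-out lower numbers stand for stronger inhibition and higher numbers for weaker inhibition:
- Compound 1 `CC(=O)O[C@@]1(C)C/C=C2\O[C@H](C[C@@H]2C)C[C@]2(C)O[C@H]2C(=O)C(=C(C)C)CC1`: > 50000 nM (a limit)
- Compound 2 `CC(=O)O[C@@]1(C)CCC(=O)[C@H](C)CCC[C@]2(C)O[C@H]2C(=O)C(=C(C)C)CC1`: 31900 nM
- Compound 3 `CC(C)=C1CC[C@]2(C)CC[C@]3(O[C@H](C[C@H]3C)C[C@]3(C)O[C@H]3C1=O)O2`: > 50000 nM (a limit)

Compound 2 is the only one of the three with a true number, 31900 nM. The rest of the picture is the limit of > 50000 nM in this assay, at which 2 of the 3 values shown sit.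

Compound 4 `CC(=O)O[C@@]1(C)CCC(=O)[C@@H](C)CCC[C@]2(C)O[C@H]2C(=O)C(=C(C)C)CC1` is built from the same parts as compound 2: the two compounds have the same atoms and bonds and differ only in configuration as drawn: 1 of 4 stereo elements differ; a stereocentre at a saturated ring carbon is drawn R in compound 2 and S in compound 4. Only the spatial arrangement at that one carbon is reversed. Among the measured compounds shown here, no measured pair here shows what such a reversal does in this assay, so no change beyond the scatter is expected. The expected step of a 1.1-fold higher number from compound 2 to compound 4 (0.04 log units; within the scatter) is therefore small. Compound 4 is estimated at 35000 nM, with an expected range of 18000 nM to 50000 nM.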

Compound 4, half-maximal inhibitory concentration: 23100 nM
For compound 4 the middle estimate is 1.5-fold (0.18 log units) above the measured one, within the range that was stated.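

In this assay, among the compounds shown here, the reversal at this one saturated ring carbon gives a 1.4-fold lower number from compound 2 to compound 4 (0.14 log units; within the scatter) and this is the first step in the set that can be read at all. Drawing this carbon R or S therefore makes no difference that stands out from the usual scatter of this read-out. The earlier compounds shown here offered no pair that differed in one place, so they could not show this. Still open, as far as these compounds go, is whether reversing any of the other stereo elements would matter in the same way. From the compounds shown here alone, it is also open whether an amine or a carboxylic acid on the shared core would change the number.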